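Methyl to Nitro on the Aromatic Ring: Rat Toxicity

A few compounds are considered here, and "the series" means these few. Any claim that something is new, unique, unknown or untested is made for them only; others in the source may bear on it.

Of the compounds shown here, three have so far been measured in a toxicity assay on the whole organism with Rattus norvegicus as the target, at a dose of 400 mg/kg by the oral route; on this read-out lower numbers stand for a weaker effect and higher numbers for a stronger effect at the one dose given. Compound 1 `Cc1ccccc1OCC1=NCCO1` gives 100% in this assay. Compound 2 `Cc1cccc(OCC2=NCCO2)c1` gives 90% in this assay; compound 1 and compound 2 have the same atoms joined differently, and the difference between the two cores is not broken down here. Compound 3 `O=[N+]([O-])c1ccccc1OCC1=NCCO1` gives 90% in this assay. The change from compound 1 to compound 3 is nitro in place of methyl on an aromatic carbon and produced a number 10 percentage points lower from compound 1 to compound 3 (within the scatter). Compound 2 and compound 3 stand at the same value within the scatter, and together they hold the lowest two of the three numbers, while compound 1 sits within the scatter of both.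

Compound 4 `O=[N+]([O-])c1cccc(OCC2=NCCO2)c1` remains to be measured in this assay. It differs from compound 2 by nitro in place of methyl on an aromatic carbon. This is the same kind of change as that from compound 1 to compound 3, but the place is not identical: in compound 4 the nitro group is meta to a group of 7 heavy atoms, whereas in compound 3 it is ortho to a group of 7 heavy atoms. Because a number 10 percentage points lower from compound 1 to compound 3 (within the scatter) lay within the scatter, the step from compound 2 to compound 4 is expected to be about no change at the digits printed from compound 2 to compound 4 (within the scatter) in this assay. Compound 4 is therefore estimated to give 90% in this assay, expected to fall between 70% and 100%.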

Compound 4, a percentage reported as activity, at one dose (the size of the read-out at that dose, not a potency): 55%
Compound 4: middle estimate off by 35 percentage points, on the high side, and the stated range ends above it.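

In this assay, nitro in place of methyl on an aromatic carbon, meta to a group of 7 heavy atoms, gave a number 35 percentage points lower from compound 2 to compound 4 (beyond the scatter). The change therefore did not carry over with one size from one core to the other in this series: the same change on two cores in this assay, a number 10 percentage points lower (within the scatter) from compound 1 to compound 3 and a number 35 percentage points lower (beyond the scatter) from compound 2 to compound 4, 25 percentage points apart, beyond the scatter of two such steps This shows that a step read on the core of compound 1 could not stand in for the step on the core of compound 2, but it does not show what separates the two steps, and two pairs of compounds set no rule for any further core.

The compounds shown carry only methyl or nitro on the aromatic ring, so it stays open how an amine, a carboxylic acid or a longer chain at the same places would read in this assay. On these data alone, it also stays open whether either of those groups would show the same dependence on the core as nitro does here.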